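Changing the Chain Terminus of a Diphenyl Imidazole Inhibitor

The source may report more compounds than this note shows. Statements on the series, on what has been measured and on what is new or still open speak of the compounds shown alone.

Compound 3 `Cc1nc(-c2ccccc2)c(-c2ccccc2)n1CCCCCCC(=O)N(C)C` gives the lowest number of the three measured compounds in an assay on H4 cells for inhibition of Fatty-acid amide hydrolase 1 (Homo sapiens) (a lower number here means a stronger inhibitor, a higher number a weaker inhibitor), with 970 nM. Its nearest neighbour is compound 2 `CNC(=O)CCCCCCn1c(C)nc(-c2ccccc2)c1-c1ccccc1`, which in this assay gives 1700 nM; the step of a 1.8-fold lower number from compound 2 to compound 3 (0.24 log units; within the scatter) is within the scatter, so the two cannot be ranked. Compound 1 `CCOC(=O)CC(CC)CCCCCn1c(C)nc(-c2ccccc2)c1-c1ccccc1` gives 9900 nM, and the steps of a 5.8-fold lower number from compound 1 to compound 2 (0.77 log units; beyond the scatter) and a 10-fold lower number from compound 1 to compound 3 (1.01 log units; beyond the scatter) show that replacing the ester-bearing branch with a carbamoyl group at the end of the chain lowers the number clearly.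

Compound 4 `Cc1nc(-c2ccccc2)c(-c2ccccc2)n1CCCCCCNC(=O)Nc1ccccc1` carries a further change at the chain terminus: (phenylcarbamoyl)amino in place of dimethylcarbamoyl on a saturated chain carbon, six bonds along the chain from an aromatic nitrogen. The measured steps concern only the terminal carbonyl group and its substitution, and the change from compound 3 to compound 4 moves well beyond them, adding a ring and two donors. The step of a 10-fold lower number from compound 1 to compound 3 (1.01 log units; beyond the scatter) shows that a carbamoyl group at the chain end already lowered the number clearly. For compound 4 the expected step is a 1.6-fold lower number from compound 3 to compound 4 (0.21 log units; within the scatter), which is expected to fall within the scatter. Compound 4 is therefore estimated at 600 nM, between 120 nM and 3000 nM.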

Compound 4, half-maximal inhibitory concentration: 10000 nM
The estimate for compound 4 lay 17-fold (1.22 log units) below the measured number, and the stated range ends below it.
By their numbers in this assay, from the lowest: compounds 3 and 2 (each within the scatter of the next); then compounds 1 and 4 (each within the scatter of the next).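

At the chain terminus, on a saturated chain carbon six bonds along the chain from an aromatic nitrogen, (phenylcarbamoyl)amino in place of dimethylcarbamoyl gives a 10-fold higher number from compound 3 to compound 4 (1.01 log units; beyond the scatter) in this assay and in place of methylcarbamoyl gives a 5.9-fold higher number from compound 2 to compound 4 (0.77 log units; beyond the scatter) at the same place. With a 1.0-fold higher number from compound 1 to compound 4 (0.00 log units; within the scatter) compound 4 cannot be ranked against compound 1, so a carbonyl group at the chain end does not lower the number on its own account, and compound 4 goes against the trend set by compound 2 and compound 3. Nothing available here accounts for this rise.

The change brings in the phenyl ring and the new chain-bound nitrogen together, and the compounds shown do not separate the two. As far as these compounds go, whether a cyclohexyl group in place of the phenyl, or a shorter chain carrying (phenylcarbamoyl)amino, would give a lower number remains open.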